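The compounds below may be only part of what the source reports. "The series", "measured", "known", "first", "only" and "open" are said of these compounds alone.

Values measured so far in a functional assay on MIA PaCa-2 cells (Homo sapiens) for antiproliferative activity (on this read-out higher numbers stand for an effect only at larger amounts of compound and lower numbers for an effect already at smaller amounts), are
Compound 1 `Cc1cc2c(C(N)=O)cccc2n1-c1nc2c(c(NCc3ccccc3)n1)COCC2` gives 146 nM
Compound 2 `Cc1cc2c(C(=O)NCCC#N)cccc2n1-c1nc2c(c(NCc3ccccc3)n1)CCCC2` gives 517 nM
Compound 3 `CCCNC(=O)c1cccc2c1cc(C)n2-c1nc2c(c(NCc3ccccc3)n1)CCCC2` gives 608 nM

Compound 1 has the lowest number of the three, and compound 2 and compound 3 both lie above it by more than the usual scatter. Compound 4 `C#CCNC(=O)c1cccc2c1cc(C)n2-c1nc2c(c(NCc3ccccc3)n1)COCC2` keeps the core of compound 1 and takes a single change, carbamoyl to propargylcarbamoyl, which reads propargyl in place of hydrogen on an amide-type nitrogen in full.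

Within the data shown here, no measured step covers this change directly. The only one available, a 1.2-fold higher number from compound 2 to compound 3 (0.07 log units; within the scatter) for methyl in place of cyano on a saturated chain carbon, alters the end of the chain on the amide-type nitrogen and stays within the scatter. Compound 2 at 517 nM and compound 3 at 608 nM both carry such a chain, as compound 4 does, and both show higher numbers than compound 1. Their core differs from that of compound 1, however, and the data do not separate the two differences. A moderately higher number is therefore expected in this assay and the uncertainty is wide. The expected step is a 2.4-fold higher number from compound 1 to compound 4 (0.38 log units; beyond the scatter) by this estimate. For compound 4 the estimated value is 350 nM with an expected range from 130 nM to 900 nM in this assay.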

Compound 4, half-maximal effective concentration: 1080 nM
Beside the measured number, compound 4's estimate is 3.1-fold (0.49 log units) below it; the measured number lies above the stated range.
By their numbers in this assay, from the lowest: compound 1; then compounds 2, 3 and 4 (each within the scatter of the next, the first and the last beyond it).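

With the core of compound 1 held fixed, propargyl in place of hydrogen on the amide-type nitrogen gives a 7.4-fold higher number from compound 1 to compound 4 (0.87 log units; beyond the scatter) in this assay, so this position does not tolerate the change without a clear shift to a higher number. Among these compounds, the earlier compounds could not show this: the one step among them, a 1.2-fold higher number from compound 2 to compound 3 (0.07 log units; within the scatter), altered only the end of a chain already present, on a different core, and left open what placing a chain on this nitrogen does by itself. The new step isolates that substitution on a single core, but nothing shown here gives a cause for its size.

The compounds shown leave open whether the same step would appear on the core of compounds 2 and 3, since no plain carbamoyl compound on that core is among them. They also leave open whether the higher number belongs to propargyl in particular or to any substituent on this nitrogen, as a methyl, a longer chain, or a chain ending in an amine or a carboxylic acid could tell.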